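The compounds below may be only part of what the source reports. "The series", "measured", "known", "first", "only" and "open" are said of these compounds alone.

The measured compounds, with their values in a functional assay on a cell-free system (plasma) for inhibition of thromboxane A2 receptor (Homo sapiens), read by turbidimetry; on this read-out higher numbers stand for weaker inhibition and lower numbers for stronger inhibition:

Compound 1, `Cc1ccc(S(=O)(=O)N[C@H]2CC[C@@H](F)[C@@H]2C/C=C\CCCC(=O)O)cc1`: 260 nM
Compound 2, `Cc1ccc(S(=O)(=O)N[C@H]2CC[C@@H](F)[C@@H]2C/C=C\CCC(=O)O)cc1`: 1900 nM
Compound 3, `Cc1ccc(S(=O)(=O)N[C@H]2CCC=C2C/C=C\CCCC(=O)O)cc1`: 250 nM

Compounds 1 and 2 share the saturated core carrying the fluorine substituent and differ in one place only: carboxy in place of carboxymethyl on a saturated chain carbon, two bonds along the chain from a double-bonded chain carbon. This shortening of the acid chain is accompanied by a 7.3-fold higher number from compound 1 to compound 2 (0.86 log units; beyond the scatter), a step that lies beyond the usual scatter of this assay.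

Compound 3 carries an unsaturated core in place of the saturated, fluorine-bearing core of compound 1; the difference between the two cores is not broken down here. The two values, compound 1 at 260 nM and compound 3 at 250 nM, lie within the scatter of each other, so nothing can be said about which of them is inhibited more strongly.

Compound 4, `Cc1ccc(S(=O)(=O)N[C@H]2CCC=C2C/C=C\CCC(=O)O)cc1`, has not yet been measured. It stands to compound 3 as compound 2 stands to compound 1: carboxy in place of carboxymethyl on a saturated chain carbon, two bonds along the chain from a double-bonded chain carbon. The place of the change is described in the same words for both pairs, so this is the same change made on a different core. Among the measured compounds shown here, because the only measured instance of this change gave a 7.3-fold higher number from compound 1 to compound 2 (0.86 log units; beyond the scatter), the change from compound 3 to compound 4 is expected to read as a 7.2-fold higher number from compound 3 to compound 4 (0.86 log units; beyond the scatter), with the single precedent as its only support. On that basis compound 4 is estimated at 1800 nM, with a range from 700 nM to 5000 nM.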

Compound 4, half-maximal inhibitory concentration: 1800 nM
Compound 4: middle estimate and measured number agree at the digits printed; the range from low to high includes it.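

In this assay, replacing carboxymethyl with carboxy on the unsaturated core gives a 7.2-fold higher number from compound 3 to compound 4 (0.86 log units; beyond the scatter) and so the step seen on the saturated, fluorine-bearing core recurs at the same size: the same change on two cores in this assay, a 7.3-fold higher number (0.86 log units; beyond the scatter) from compound 1 to compound 2 and a 7.2-fold higher number (0.86 log units; beyond the scatter) from compound 3 to compound 4, 1.0-fold (0.01 log units) apart, within the scatter of two such steps. Across these two pairs, the change therefore carries from one core to the other without a difference that can be told from the scatter, and the shorter acid chain goes with weaker inhibition on both. Among the compounds shown here, this shows only that the step transfers between two related cores in a single assay; it does not establish that the step would keep its size on a third core, and it gives no explanation of why the shorter chain reads weaker.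

The compounds shown leave open how a longer acid chain than that of compound 1 and compound 3 would read, and whether an amide or a tetrazole could stand in place of the carboxylic acid. For the compounds shown here, they also leave open what the fluorine and the ring double bond each contribute, since the two cores differ in both features and no compound here separates them.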